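Amide aryl variation: notes toward compound 4

The compounds below may be only part of what the source reports. "The series", "measured", "known", "first", "only" and "open" are said of these compounds alone.

Measured so far:
compound 1 `COc1ccc(C(=O)Nc2cccc(-c3oc4cc(-c5ccc(F)cc5)ccc4c(=O)c3O)c2)cc1`: 16500 nM
compound 2 `O=C(Nc1cccc(-c2oc3cc(-c4ccc(F)cc4)ccc3c(=O)c2O)c1)c1cccc(F)c1`: 2510 nM
compound 3 `COc1ccc(C(=O)Nc2cccc(-c3oc4cc(-c5ccc(F)cc5)ccc4c(=O)c3O)c2)c(F)c1`: 17600 nM

In a functional assay on MDA-MB-231 cells (Homo sapiens) for antiproliferative activity, read by CCK-8 assay, with a stated time of 72 h (a lower number here means a stronger inhibitor, a higher number a weaker inhibitor), compound 3 gives the highest number of the three; compound 1 sits close, a 1.1-fold higher number from compound 1 to compound 3 (0.03 log units; within the scatter), while compound 2 stands well apart, a 7.0-fold higher number from compound 2 to compound 3 (0.85 log units; beyond the scatter). Compound 4 `COc1cc(OC)cc(C(=O)Nc2cccc(-c3oc4cc(-c5ccc(F)cc5)ccc4c(=O)c3O)c2)c1` alters only the amide aryl: 3,5-dimethoxyphenyl in place of 2-fluoro-4-methoxyphenyl on a carbonyl carbon. Among the compounds with values here, two measured steps bear on this. a 1.1-fold higher number from compound 1 to compound 3 (0.03 log units; within the scatter) shows the two methoxy-bearing aryls giving numbers within the scatter of each other, and a 6.6-fold lower number from compound 1 to compound 2 (0.82 log units; beyond the scatter) shows the aryl lacking methoxy as the only one giving a modest gain. Compound 4 retains methoxy, so little movement from compound 3 is expected. The expected step is small, a 1.5-fold lower number from compound 3 to compound 4 (0.17 log units; within the scatter). Compound 4 is expected at 12000 nM, between 4000 nM and 30000 nM.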

Compound 4, half-maximal inhibitory concentration: 4040 nM
For compound 4 the middle estimate is 3.0-fold (0.47 log units) above the measured one; the range from low to high includes it.
By their numbers in this assay, from the lowest: compounds 2 and 4 (each within the scatter of the next); then compounds 1 and 3 (each within the scatter of the next).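

In this assay a methoxy-bearing aryl is no longer tied to the weaker numbers: the series shows a 4.4-fold lower number from compound 3 to compound 4 (0.64 log units; beyond the scatter) and a 4.1-fold lower number from compound 1 to compound 4 (0.61 log units; beyond the scatter) with the 3,5-dimethoxyphenyl amide. Methoxy on this aryl is thus compatible with a number close to that of the 3-fluorophenyl amide, as a 1.6-fold higher number from compound 2 to compound 4 (0.21 log units; within the scatter) leaves the two within the scatter. No available evidence accounts for this shift.

Whether the gain follows the count of methoxy groups or their placement stays open, as the 3-methoxyphenyl amide is not among the compounds shown. On these data alone, how an amine or a carboxylic acid on this aryl would read also remains open.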